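Replacing the methoxybenzyl amide with a hexyl chain

The source may report more compounds than this note shows. Statements on the series, on what has been measured and on what is new or still open speak of the compounds shown alone.

Of the compounds shown here, three sharing one core have been measured in a functional assay on REH cells (Homo sapiens) for cytotoxicity, read by MTT assay, with a stated time of 72 h; a lower number here means a stronger inhibitor, a higher number a weaker inhibitor. Compound 1 `N#Cc1ccc(NC(=O)CN2C(=O)/C(=C/c3ccc(-c4ccc(Cl)cc4)o3)SC2=S)cc1` gives 90000 nM, compound 2 `O=C(CN1C(=O)/C(=C/c2ccc(-c3ccc(Cl)cc3)o2)SC1=S)NCc1ccc(F)cc1` gives 165000 nM, and compound 3 `COc1ccc(CNC(=O)CN2C(=O)/C(=C/c3ccc(-c4ccc(Cl)cc4)o3)SC2=S)cc1` gives 44000 nM. Compound 3 thus has the lowest number of the three: the step of a 2.0-fold lower number from compound 1 to compound 3 (0.31 log units; beyond the scatter) is modest but beyond the scatter, and the step of a 3.8-fold lower number from compound 2 to compound 3 (0.57 log units; beyond the scatter) is the larger of the two, while the step of a 1.8-fold higher number from compound 1 to compound 2 (0.26 log units; within the scatter) stays within the scatter.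

Compound 4 `CCCCCCNC(=O)CN1C(=O)/C(=C/c2ccc(-c3ccc(Cl)cc3)o2)SC1=S` differs from compound 3 in one place: pentyl in place of 4-methoxyphenyl on a saturated chain carbon bound to an amide-type nitrogen. Among the compounds with values here, no measured step removes the aromatic ring from this amide substituent altogether; the steps that bear on it only swap one aryl group for another or one ring substituent for another, and they move the numbers by modest amounts, as a 3.8-fold lower number from compound 2 to compound 3 (0.57 log units; beyond the scatter) shows. Since the substituent that gave the lowest number is removed, a modest rise is expected in this assay, though with considerable uncertainty. Compound 4 is expected to give about 90000 nM, within a range of 30000 nM to 270000 nM, which would mean a step of a 2.0-fold higher number from compound 3 to compound 4 (0.31 log units; beyond the scatter).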

Compound 4, half-maximal inhibitory concentration: 55000 nM
The estimate for compound 4 lay 1.6-fold (0.21 log units) above the measured number; low and high end bracket the measured number.
By their numbers in this assay, from the lowest: compounds 3, 4, 1 and 2 (each within the scatter of the next, the first and the last beyond it).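

In this assay, an amide substituent with no ring at all holds its place among the aromatic ones: hexyl cannot be told apart from 4-methoxybenzyl (a 1.3-fold higher number from compound 3 to compound 4 (0.10 log units; within the scatter)) or from 4-cyanophenyl (a 1.6-fold lower number from compound 1 to compound 4 (0.21 log units; within the scatter)). The one clear separation is from 4-fluorobenzyl (a 3.0-fold lower number from compound 2 to compound 4 (0.48 log units; beyond the scatter)), so the ring-bearing substituents do not stand as a group on one side of the open chain, with compound 2 set apart from compound 3 and compound 4 while compound 1 stays within the scatter of both. No measurement is available that would account for these numbers.

The compounds shown leave open how the number responds to chain length, for instance with a shorter butyl or a longer octyl chain on the amide nitrogen. They also leave open whether a hexyl chain ending in an amine or a carboxylic acid would keep compound 4's number of 55000 nM or shift it clearly away from that of compound 3.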